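Adding a third methoxy group: solubility of compound 4

This account rests on a few compounds, and the source may have more. Where it says the series, first, only, none or still open, it means among the compounds named here.

Three close relatives of a shared core have been measured in a physicochemical assay for solubility, at pH 6.9; on this read-out lower numbers stand for lower solubility and higher numbers for higher solubility. Compound 1, `O=C(CN1CCN(c2cc3c(cc2F)c(=O)c(C(=O)O)cn3C2CC2)CC1)Nc1ccc(C(=O)/C=C/c2ccc(Cl)cc2)cc1`, gives 2.77 ug/mL. Compound 2, `COc1ccc(/C=C/C(=O)c2ccc(NC(=O)CN3CCN(c4cc5c(cc4F)c(=O)c(C(=O)O)cn5C4CC4)CC3)cc2)cc1`, gives 2.98 ug/mL. Compound 3, `COc1ccc(/C=C/C(=O)c2ccc(NC(=O)CN3CCN(c4cc5c(cc4F)c(=O)c(C(=O)O)cn5C4CC4)CC3)cc2)cc1OC`, gives 0.75 ug/mL, the lowest of the three numbers; the steps of a 3.7-fold lower number from compound 1 to compound 3 (0.57 log units; beyond the scatter) and a 4.0-fold lower number from compound 2 to compound 3 (0.60 log units; beyond the scatter) both lie beyond the scatter, while the step of a 1.1-fold higher number from compound 1 to compound 2 (0.03 log units; within the scatter) does not.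

Compound 4, `COc1cc(/C=C/C(=O)c2ccc(NC(=O)CN3CCN(c4cc5c(cc4F)c(=O)c(C(=O)O)cn5C4CC4)CC3)cc2)cc(OC)c1OC`, carries one change relative to compound 3: methoxy in place of hydrogen on an aromatic carbon. The nearest comparison is the earlier addition of a methoxy group, seen in the step of a 4.0-fold lower number from compound 2 to compound 3 (0.60 log units; beyond the scatter), which lowered the number by a modest amount. One step is thin evidence, and compound 1 going to compound 2 shows that not every change of this kind moves the number. Among the measured compounds shown here, still, the direction of the measured methoxy addition is the only guide available, so a further modest fall is expected rather than a rise. The estimate for compound 4 is 0.35 ug/mL, with a range from 0.12 ug/mL to 1 ug/mL, which means an expected step of a 2.1-fold lower number from compound 3 to compound 4 (0.33 log units; beyond the scatter).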

Compound 4, solubility: 2.13 ug/mL
Beside the measured number, compound 4's estimate is 6.1-fold (0.78 log units) below it; the whole stated range lies below it.
By their numbers in this assay, from the lowest: compound 3; then compounds 4, 1 and 2 (each within the scatter of the next).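

In this assay, one and the same change, methoxy in place of hydrogen on an aromatic carbon, lowered the number at first (a 4.0-fold lower number from compound 2 to compound 3 (0.60 log units; beyond the scatter)) but raises it when the new methoxy goes ortho to a methoxy group already on the ring (a 2.8-fold higher number from compound 3 to compound 4 (0.45 log units; beyond the scatter)). Adding a methoxy group to this ring therefore has no fixed direction on this read-out. The 3,4,5-trimethoxyphenyl ring reads the same, within the scatter, as both 4-methoxyphenyl (a 1.4-fold lower number from compound 2 to compound 4 (0.15 log units; within the scatter)) and 4-chlorophenyl (a 1.3-fold lower number from compound 1 to compound 4 (0.11 log units; within the scatter)), which leaves the 3,4-dimethoxyphenyl compound alone at the low end.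

Nothing available here explains this reversal. The compounds shown also leave open how this ring would read with a dimethylamino group or a carboxylic acid on it.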